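Chloro for methyl on compound 1

The source may hold more compounds than are shown below. What is called first, only, known or untested is meant among the compounds shown, and "the series" means these compounds.

Measured in a physicochemical assay for solubility, measured as kinetic solubility, at pH 2; a lower number here means a less soluble compound, a higher number a more soluble compound:
- compound 1 `Cc1cc(C(/C=C2\OC(=O)NC2=O)C(C)C)c(=O)[nH]c1-c1ccc2cccc(F)c2c1` gives 39400 nM
- compound 2 `CC(C)C(/C=C1\SC(=O)NC1=O)c1ccc(-c2ccc3cccc(F)c3c2)[nH]c1=O` gives 4800 nM

Going by the values given here, of the two compounds measured so far, compound 1 stands highest, at 39400 nM against compound 2 at 4800 nM, a gap beyond the scatter. These two compounds differ in more than one place, so their gap does not size any single change.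

Compound 3 `CC(C)C(/C=C1\OC(=O)NC1=O)c1cc(Cl)c(-c2ccc3cccc(F)c3c2)[nH]c1=O` has not yet been measured. It keeps the rest of compound 1 and carries chloro in place of methyl on an aromatic carbon on the six-membered aromatic ring with 1 nitrogen. Among the compounds with values here, no measured pair shows this swap, so the expectation rests on compound 1 at 39400 nM as its only anchor. One heavy atom replaces one heavy atom, and in this assay no step beyond the scatter is expected. The estimated 1.3-fold lower number from compound 1 to compound 3 (0.12 log units; within the scatter) is therefore small. Compound 3 is estimated at 30000 nM with an expected range of 10000 nM to 70000 nM in this read-out.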

Compound 3, solubility: 3200 nM
Compound 3: middle estimate off by 9.4-fold (0.97 log units), on the high side, and the stated range ends above it.
By their numbers in this assay, from the lowest: compounds 3 and 2 (each within the scatter of the next); then compound 1.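

At the aromatic carbon two atoms from the ring nitrogen, ortho to a large group, chloro in place of methyl gives in this assay a 12-fold lower number from compound 1 to compound 3 (1.09 log units; beyond the scatter) on an otherwise unchanged structure. Going by these compounds alone, this is the first size that can be read for a single change, since compound 1 and compound 2 differ in more than one place. It shows that exchanging one heavy atom for one heavy atom at this position, with no ring, hydrogen-bond donor, hydrogen-bond acceptor or net charge entering or leaving, is enough to carry the read-out beyond the scatter, and no measurement at hand bears on why.

The compounds shown leave open whether the step comes from losing methyl or from gaining chloro, a question that other groups on the same carbon, such as a bromo, a methoxy or an amine, could help to settle. They also leave open whether chloro in place of methyl gives a step of similar size when the core of compound 1 is changed elsewhere.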